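Compound 1 to compound 4: methyl for trifluoromethyl

A few compounds are considered here, and "the series" means these few. Any claim that something is new, unique, unknown or untested is made for them only; others in the source may bear on it.

In a functional assay on HCT-116 cells (Homo sapiens) for cytotoxicity, read by MTT assay, with a stated time of 48 h, in the presence of a further agent that is not named here (on this read-out higher numbers stand for an effect only at larger amounts of compound and lower numbers for an effect already at smaller amounts), compound 1 `Cn1nc(C(F)(F)F)c2c(-c3ccccc3)cc(NNC(=O)Nc3cc(Cl)nc(Cl)c3)nc21` gives 18100 nM. Compound 3 `CC(C)c1cc(NNC(=O)Nc2cc(Cl)nc(Cl)c2)nc2c1c(C(F)(F)F)nn2C` gives 27200 nM, and the two cannot be separated: a 1.5-fold higher number from compound 1 to compound 3 (0.18 log units; within the scatter), with isopropyl in place of phenyl on an aromatic carbon. Compound 2 `Cn1ncc2c(-c3ccc(F)cc3)cc(NNC(=O)Nc3cc(Cl)nc(OCCF)c3)nc21` gives 37200 nM, a higher number than that of compound 1, and the gap lies just beyond the scatter. Compound 1 thus sits at the low end of a narrow set of numbers, level with compound 3.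

The next step leads to compound 4 `Cc1nn(C)c2nc(NNC(=O)Nc3cc(Cl)nc(Cl)c3)cc(-c3ccccc3)c12`, with methyl in place of trifluoromethyl on an aromatic carbon of a five-membered aromatic ring with 2 nitrogen: methyl in place of trifluoromethyl on an aromatic carbon. For the measured compounds named here, no measured step touches this place. Going by the values given here, the one single-place step, at a 1.5-fold higher number from compound 1 to compound 3 (0.18 log units; within the scatter), concerns another group and gives only a rough sense of how little the numbers have moved so far. Compound 2 carries no trifluoromethyl, but it differs from compound 1 in other places too, so compound 2 at 37200 nM is weak evidence for a slight rise at most. The expected change is small, a 1.3-fold higher number from compound 1 to compound 4 (0.12 log units; within the scatter), and no step beyond the scatter is anticipated. For compound 4 the estimated value in this assay is 24000 nM, with an expected range of 10000 nM to 55000 nM.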

Compound 4, half-maximal effective concentration: 80000 nM
Compound 4: middle estimate off by 3.3-fold (0.52 log units), on the low side; the measured number lies above the stated range.
By their numbers in this assay, from the lowest: compounds 1, 3 and 2 (each within the scatter of the next, the first and the last beyond it); then compound 4.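

Methyl in place of trifluoromethyl on this aromatic carbon gives a 4.4-fold higher number from compound 1 to compound 4 (0.65 log units; beyond the scatter) in this assay, so this place on the five-membered aromatic ring with 2 nitrogen is one where a single change moves the number beyond the scatter. For the compounds shown here, the only earlier single-place step, a 1.5-fold higher number from compound 1 to compound 3 (0.18 log units; within the scatter), stayed within the scatter and concerned another group, so it gave no sign of this; with the rest of compound 1 held constant, the higher number goes with the loss of trifluoromethyl, and a single pair defines the direction of the change at this place. No measurement at hand gives a basis for explaining the step.

As far as these compounds go, with only trifluoromethyl and methyl compared directly here, it remains open how other groups at this carbon, such as ethyl, difluoromethyl or a nitrile, would read, since compound 2 lacks the trifluoromethyl but differs in other places as well. From the compounds shown here alone, it also remains open whether the same change gives a step of similar size when isopropyl stands in place of phenyl, as in compound 3, or in other cell lines.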